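The compounds below may be only part of what the source reports. "The series", "measured", "known", "first", "only" and "open" are said of these compounds alone.

Compound 1 `O=C1CC(c2nc(-c3cccc(Cl)c3)no2)CN1c1ccc(Cl)cc1` gives > 10000 nM in an in vitro functional assay on HEK293-A cells for negative allosteric modulation of metabotropic glutamate receptor 5 (Homo sapiens), read by FLIPR and calcium flux; on this read-out lower numbers stand for stronger inhibition and higher numbers for weaker inhibition; this value is a limit.
Compound 2 `Cc1ccc(N2CC(c3nc(-c4cccc(Cl)c4)no3)CC2=O)cc1C` gives > 10000 nM in this assay; this value is a limit.

Compound 2 stands at the limit of this assay, where both measured values sit (the limit of > 10000 nM in this assay, at which 2 of the 2 values shown sit). Going by the values given here, the single measured step, a step that the two limits leave unreadable from compound 1 to compound 2, cannot be read. Compound 3 `Cc1ccccc1N1CC(c2nc(-c3cccc(Cl)c3)no2)CC1=O` arises through the change (2-methylphenyl in place of 3,4-dimethylphenyl on an amide-type nitrogen in a ring). Among the compounds with values here, no measured step bears readably on it, as both neighbours sit at the limit. Compound 3 is expected in this assay at about 10000 nM, between 3000 nM and 30000 nM. The expected step is therefore a number no higher from compound 2 to compound 3 (the limit leaves the size open), most likely once more reported only as a limit.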

Compound 3, half-maximal inhibitory concentration: 370 nM
The estimate for compound 3 lay 27-fold (1.43 log units) above the measured number; measured number outside the range, below it.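

On the amide-type nitrogen in a ring, the choice of aryl group separates a readable number from none in this assay. 2-Methylphenyl in place of 3,4-dimethylphenyl gives an at least 27-fold lower number from compound 2 to compound 3 (1.43 log units; beyond the scatter), and 2-methylphenyl in place of 4-chlorophenyl gives an at least 27-fold lower number from compound 1 to compound 3 (1.43 log units; beyond the scatter). Compound 3 is the only one of the three whose value is not a limit: the limit of > 10000 nM in this assay, at which 2 of the 3 values shown sit.

On these data alone, what a plain phenyl, a 2-chlorophenyl or a 2-methoxyphenyl would give on this nitrogen stays open. Also open, as far as these compounds go, is whether the number of compound 3 holds when the shared core is changed elsewhere.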